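Replacing the hydroxy group of compound 2

A few compounds are considered here, and "the series" means these few. Any claim that something is new, unique, unknown or untested is made for them only; others in the source may bear on it.

Among the measured compounds shown here, compound 2 `CCCC(Nc1cncc(-c2ccc(O)c(OC)c2)n1)c1cccnc1` stands lowest of the two numbers so far in a functional assay on DU-145 cells (Homo sapiens) for cytotoxicity, read by MTT assay, with a stated time of 72 h; on this read-out lower numbers stand for stronger inhibition and higher numbers for weaker inhibition: compound 2 gives 600 nM, while compound 1 `CCCC(Nc1cncc(-c2ccc(O)c(OC)c2)n1)c1ccc(Cl)cc1` gives 10000 nM. For the measured compounds named here, the one measured step, a 17-fold lower number from compound 1 to compound 2 (1.22 log units; beyond the scatter), is large, but it comes from pyridin-3-yl in place of 4-chlorophenyl on a saturated chain carbon, which is a different place. Compound 3 `CCCC(Nc1cncc(-c2ccc(NC(=O)NCC)c(OC)c2)n1)c1cccnc1` keeps that pyridin-3-yl and carries (ethylcarbamoyl)amino in place of hydroxy on an aromatic carbon, ortho to a methoxy group: (ethylcarbamoyl)amino in place of hydroxy on an aromatic carbon. Going by the values given here, no measured step covers this place, so a 17-fold lower number from compound 1 to compound 2 (1.22 log units; beyond the scatter) shows only that a single change can move this assay strongly, and it sets no size here. A moderate move towards a higher number is expected, an estimated 2.5-fold higher number from compound 2 to compound 3 (0.40 log units; beyond the scatter), with wide uncertainty. For compound 3 the estimated value is 1500 nM, within an expected range from 250 nM to 8000 nM.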

Compound 3, half-maximal inhibitory concentration: 60 nM
Beside the measured number, compound 3's estimate is 25-fold (1.40 log units) above it, and the stated range ends above it.
By their numbers in this assay, from the lowest: compound 3; then compound 2; then compound 1.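

In this assay, among the compounds shown here, the change at this aromatic carbon, ortho to a methoxy group, gives a 10-fold lower number from compound 2 to compound 3 (1.00 log units; beyond the scatter) and is the first measured step at this place, as the earlier step lay on the saturated chain carbon. It shows that hydroxy is not required here for a low number, and that the position accepts the larger (ethylcarbamoyl)amino group with a fall in the number rather than a rise. Nothing available explains why this exchange lowers the number.

The compounds shown leave open which part of the (ethylcarbamoyl)amino group matters, as no plain amino group, acetylamino group or longer chain in place of ethyl stands among them. They also leave open whether the same exchange would lower the number with 4-chlorophenyl on the saturated chain carbon.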